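Replacing Diisopropylamino with a Nitrobenzoyl Ester

A few compounds are considered here, and "the series" means these few. Any claim that something is new, unique, unknown or untested is made for them only; others in the source may bear on it.

Going by the values given here, compound 2 (`CC(C)=CCC[C@]1(C)/C=C/[C@@H](OC(=O)C=C(C)C)[C@](C)(O)/C=C/C(=O)/C(CN(C(C)C)C(C)C)=C\C1`) gives 750 nM in a functional assay on SW480 cells (Homo sapiens) for antiproliferative activity, read by MTT assay, with a stated time of 48 h (a lower number here means a stronger inhibitor, a higher number a weaker inhibitor), the only exact number so far. Compound 1 (`CC(C)=CCC[C@]1(C)/C=C/[C@@H](OC(=O)C=C(C)C)[C@](C)(O)/C=C/C(=O)/C(C(=O)O)=C\C1`) reads > 10000 nM in this assay and this is a limit, not a number.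

Compound 3 (`CC(C)=CCC[C@]1(C)/C=C/[C@@H](OC(=O)C=C(C)C)[C@](C)(O)/C=C/C(=O)/C(COC(=O)c2ccc([N+](=O)[O-])cc2)=C\C1`) has ((4-nitrophenyl)carbonyl)oxy in place of diisopropylamino on a saturated chain carbon bound to a double-bonded ring carbon.

Among the compounds with values here, only one measured step bears on this change. Placing (diisopropylamino)methyl in place of carboxy on a double-bonded ring carbon gave an at least 13-fold lower number from compound 1 to compound 2 (1.12 log units; beyond the scatter) and this large step lies beyond the scatter. It shows that the number can move strongly with a change at this part of the shared core. However, compound 3 carries neither the carboxy of compound 1 nor the diisopropylamino of compound 2, so the step offers only a loose guide.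

A moderate move towards a weaker result is expected, given as a 3.3-fold higher number from compound 2 to compound 3 (0.52 log units; beyond the scatter) in this estimate. Compound 3 is estimated at 2500 nM with an expected range of 500 nM to 10000 nM for now.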

Compound 3, half-maximal inhibitory concentration: 570 nM
For compound 3 the middle estimate is 4.4-fold (0.64 log units) above the measured one, and the stated range covers the measured number.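

In this assay, putting ((4-nitrophenyl)carbonyl)oxy in place of diisopropylamino on a saturated chain carbon bound to a double-bonded ring carbon gave a 1.3-fold lower number from compound 2 to compound 3 (0.12 log units; within the scatter), so this read-out does not separate the two compounds. The earlier step showed only that the number can move strongly at this part of the shared core, whereas this one shows that, among the compounds shown, the diisopropylamino group is not needed for a result of this size: an ester carrying one six-membered aromatic ring serves equally well, even though the two groups share little beyond their place on the core. The comparison with compound 1 remains loose, as its value is a limit and not a number: the limit of > 10000 nM in this assay, at which 1 of the 3 values shown sits.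

A plain benzoyl ester, without the nitro group, would test whether the nitro group contributes anything to the result of compound 3. A simple hydroxyl or a ring amine such as piperidine on the same saturated chain carbon would help show how much of the group at this place can be changed or removed before the number moves beyond the scatter.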